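A few compounds are considered here, and "the series" means these few. Any claim that something is new, unique, unknown or untested is made for them only; others in the source may bear on it.

Among the compounds with values here, in a functional assay on thoracic aorta (Rattus norvegicus, strain Wistar), with a stated time of 15 min (a higher number here means that more compound is needed for the effect, a lower number that less compound is needed), compound 1 `CCOc1ccc(Cl)cc1C(C)NC(=O)N(C)S(=O)(=O)c1ccccc1` gives 10500 nM, the only true number so far. Compound 2 `CCOc1ccc(F)cc1C(C)NC(=O)NS(=O)(=O)c1ccccc1` reads > 300000 nM, which is a limit of the assay and not a number. Going by these compounds, its actual position therefore remains open.

The next compound to be read is compound 3 `CCOc1ccc(Cl)cc1C(C)NC(=O)NS(=O)(=O)c1ccccc1`. Going from compound 2 to compound 3, the change is chloro in place of fluoro on an aromatic carbon, para to an ethoxy group and meta to a large group. The rest of the structure stays the same. Within the data shown here, no measured pair isolates this exchange, so the data give no direct size for it.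

Among the measured compounds shown here, the one chloro compound with a number is compound 1 at 10500 nM, which leaves room to expect a move toward less compound needed in this assay. That move is expected to be modest, and compound 3 may well stay at the limit. The expected step is an at least 2.5-fold lower number from compound 2 to compound 3 (0.39 log units; beyond the scatter). Compound 3 is estimated at 120000 nM, with an expected range of 30000 nM to 300000 nM.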

Compound 3, half-maximal effective concentration: > 300000 nM
Compound 3: no number, only a limit; the forecaster's own chance of this, stated with the estimate: 50%; middle value at least 2.5-fold (0.39 log units) from the limit.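

With chloro in place of fluoro on the aromatic carbon para to an ethoxy group, compound 3 in this assay gives > 300000 nM, which is a limit of the assay and not a number, so the step from compound 2 cannot be read and this pair gives no size for the exchange. Chloro alone therefore does not bring the series to a true number, and the one readable change lies at another place: hydrogen in place of methyl on the amide-type nitrogen gives an at least 28-fold higher number from compound 1 to compound 3 (1.45 log units; beyond the scatter). That step rests on a single pair with chloro held fixed, and only one end of it is a number, so its full size stays hidden behind the limit of the series: the limit of > 300000 nM in this assay, at which 2 of the 3 values shown sit.

Still open, going by these compounds, is how far compound 2 and compound 3 lie beyond the limit, and whether chloro and fluoro differ at all when the nitrogen carries a methyl group. Also open, on these data alone, is how an ethyl group or a longer chain on that nitrogen would read in this assay, which would show whether methyl itself matters or any group there does.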